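From naphthalen-1-yl to 4-methylquinazolin-2-yl on one core

A few compounds are considered here, and "the series" means these few. Any claim that something is new, unique, unknown or untested is made for them only; others in the source may bear on it.

Measured so far in a functional assay on PC-9 cells (Homo sapiens) for inhibition, read by MTT assay, with a stated time of 72 h; a lower number here means a stronger inhibitor, a higher number a weaker inhibitor
- compound 1 `Cc1cc(Nc2ccn(Cc3cccc4ccccc34)n2)n2nc(SCc3ccc(Br)cc3)nc2n1` gives 5660 nM 
- compound 2 `Cc1cc(Nc2cc(-c3ccccc3)[nH]n2)n2nc(SCc3ccc(Cl)cc3)nc2n1` gives 6710 nM 

Compound 1 and compound 2 lie within the usual scatter of each other, so the numbers do not separate them. Compound 3 (`Cc1cc(Nc2ccn(Cc3nc(C)c4ccccc4n3)n2)n2nc(SCc3ccc(Br)cc3)nc2n1`) keeps the core of compound 1 and changes one group, with 4-methylquinazolin-2-yl in place of naphthalen-1-yl on a saturated chain carbon bound to an aromatic nitrogen. For the measured compounds named here, no step between measured compounds shows what such a swap does. In this assay the expected outcome is therefore no shift beyond the scatter, in either direction (a 1.1-fold higher number from compound 1 to compound 3 (0.03 log units; within the scatter)). For compound 3 the estimated value is 6000 nM (range 2000 nM to 18000 nM).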

Compound 3, half-maximal inhibitory concentration: 5450 nM
Estimate against measurement, compound 3: 1.1-fold (0.04 log units) above, within the range that was stated.
By their numbers in this assay, from the lowest: compounds 3, 1 and 2 (each within the scatter of the next).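

In this assay, putting 4-methylquinazolin-2-yl in place of naphthalen-1-yl on a saturated chain carbon bound to an aromatic nitrogen gives a 1.0-fold lower number from compound 1 to compound 3 (0.02 log units; within the scatter) on the core of compound 1. For the compounds shown here, this is the first step read at this position: the entering group has 2 hydrogen-bond acceptors and the leaving group has 0, yet the two values stay within the scatter. Nothing available explains this result.

As far as these compounds go, whether an amine or a carboxylic acid in this place would give a different value remains open. So does the effect of a longer chain leading to the 4-methylquinazolin-2-yl group.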